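Compound 3: Chloro Replaces Trifluoromethyl Beside the Other Chloro

A few compounds are considered here, and "the series" means these few. Any claim that something is new, unique, unknown or untested is made for them only; others in the source may bear on it.

For the measured compounds named here, of the two compounds measured so far, compound 2 `COc1cc2cc(Oc3ccc(NC(=O)Nc4ccc(Cl)c(C(F)(F)F)c4)cc3)c(C)nc2cc1OC` carries the lowest number in a functional assay on NCI-H322M cells (Homo sapiens) for inhibition, read by sulforhodamine B assay, with a stated time of 48 h (on this read-out lower numbers stand for stronger inhibition of growth and higher numbers for weaker inhibition of growth), as compound 2 gives 2050 nM. Its nearest neighbour is compound 1 `COc1cc2cc(Oc3ccc(NC(=O)Nc4cccc(C(F)(F)F)c4)cc3)c(C)nc2cc1OC`, and in this assay compound 1 gives 2840 nM; the step of a 1.4-fold lower number from compound 1 to compound 2 (0.14 log units; within the scatter) is within the scatter, so the two numbers cannot be told apart. Compound 3 `COc1cc2cc(Oc3ccc(NC(=O)Nc4ccc(Cl)c(Cl)c4)cc3)c(C)nc2cc1OC` has not yet been measured. It differs from compound 2 by chloro in place of trifluoromethyl on an aromatic carbon. Going by the values given here, no measured step exchanges a trifluoromethyl for a chloro; the only step available, a 1.4-fold lower number from compound 1 to compound 2 (0.14 log units; within the scatter), concerns a chloro replacing hydrogen rather than replacing a trifluoromethyl, and it moved the number by less than the scatter. With the exchange itself untested, a step from compound 2 to compound 3 of no more than the scatter is expected in either direction, and the estimate is correspondingly wide. For compound 3 the expected value in this assay is 2500 nM, with a range from 1000 nM to 6500 nM. This estimate corresponds to an expected step of a 1.2-fold higher number from compound 2 to compound 3 (0.09 log units; within the scatter).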

Compound 3, concentration for 50% growth inhibition: 8660 nM
For compound 3 the middle estimate is 3.5-fold (0.54 log units) below the measured one; measured number outside the range, above it.
By their numbers in this assay, from the lowest: compounds 2 and 1 (each within the scatter of the next); then compound 3.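

In this assay, for the compounds shown here, the place on the aromatic ring ortho to a chloro group and meta to a large group is the first to show a change beyond the scatter, with chloro in place of trifluoromethyl giving a 4.2-fold higher number from compound 2 to compound 3 (0.63 log units; beyond the scatter). The earlier step, a 1.4-fold lower number from compound 1 to compound 2 (0.14 log units; within the scatter), added a chloro while the trifluoromethyl stayed and left the two numbers indistinguishable, whereas the 3,4-dichlorophenyl group gives a 3.0-fold higher number from compound 1 to compound 3 (0.48 log units; beyond the scatter) when set against the 3-(trifluoromethyl)phenyl group. Among these compounds, then, the rise in the number appears only where the trifluoromethyl has left, and the data available give no explanation for it.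

As far as these compounds go, it remains open whether a bromo, a methyl, a methoxy or a nitrile in that same place would give a number like that of compound 2 or compound 3. From the compounds shown here alone, it is also open whether chloro in place of trifluoromethyl would have a similar effect in compound 1, which lacks the other chloro, so the step may or may not depend on that group being present.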